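This account rests on a few compounds, and the source may have more. Where it says the series, first, only, none or still open, it means among the compounds named here.

Measured in a functional assay on PC-3 cells (Homo sapiens) for cytotoxicity, read by cell counting, with a stated time of 48 h; a lower number here means a stronger inhibitor, a higher number a weaker inhibitor:
Compound 1 `Cc1ccc(-n2cc(COc3cccc4cnc(Nc5cccc(Cl)c5)nc34)nn2)c([N+](=O)[O-])c1`: 7000 nM
Compound 2 `Clc1ccc(-n2cc(COc3cccc4cnc(Nc5cccc(Cl)c5)nc34)nn2)cc1`: > 25000 nM (a limit of the assay, not a number)
Compound 3 `Clc1cccc(Nc2ncc3cccc(OCc4cn(-c5ccc(Br)cc5)nn4)c3n2)c1`: 18000 nM

Only two of these results are numbers, and the higher of the two belongs to compound 3. The gap between them is a 2.6-fold higher number from compound 1 to compound 3 (0.41 log units; beyond the scatter).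

Compound 4 `COc1cccc(-n2cc(COc3cccc4cnc(Nc5cccc(Cl)c5)nc34)nn2)c1` has not yet been measured. The change from compound 3 is 3-methoxyphenyl in place of 4-bromophenyl on an aromatic nitrogen.

Two measured steps alter the group on this same nitrogen: an at least 3.5-fold higher number from compound 1 to compound 2 (0.55 log units; beyond the scatter) and a 2.6-fold higher number from compound 1 to compound 3 (0.41 log units; beyond the scatter). Both are modest at the least, and both start from the 4-methyl-2-nitrophenyl group, which compound 4 does not carry. The third step, an at least 1.3-fold lower number from compound 2 to compound 3 (0.14 log units; that floor lies within the scatter), has a floor within the scatter and does not separate the chloro and bromo compounds. Within the data shown here, no measured compound carries 3-methoxyphenyl, so the data give no direction for this change.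

No step beyond the scatter is therefore expected in this assay, although a modest step either way remains possible. The expected step is a 1.2-fold lower number from compound 3 to compound 4 (0.08 log units; within the scatter). For compound 4 the estimate is 15000 nM, with an expected range from 6000 nM to 25000 nM.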

Compound 4, half-maximal inhibitory concentration: 10000 nM
Compound 4: the middle estimate sits 1.5-fold (0.18 log units) above what was measured; the range from low to high includes it.
By their numbers in this assay, from the lowest: compounds 1, 4 and 3 (each within the scatter of the next, the first and the last beyond it). At a limit, above all of these: compound 2.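

In this assay, among these compounds, the earlier compounds showed the two groups lacking the nitro substituent, 4-chlorophenyl and 4-bromophenyl, both beyond the scatter from the 4-methyl-2-nitrophenyl group of compound 1. With 3-methoxyphenyl on this aromatic nitrogen, that separation no longer holds for every group lacking nitro, as a 1.4-fold higher number from compound 1 to compound 4 (0.15 log units; within the scatter) and a 1.8-fold lower number from compound 3 to compound 4 (0.26 log units; within the scatter) both stay within the scatter, so compound 4 cannot be ordered against either compound. The change from 4-chlorophenyl does read beyond the scatter, an at least 2.5-fold lower number from compound 2 to compound 4 (0.39 log units; beyond the scatter), but compound 2 sits at a limit of the assay and that step is only a floor: the limit of > 25000 nM in this assay, at which 1 of the 4 values shown sits.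

It remains open whether the methoxy group itself or its place on the phenyl ring accounts for compound 4, since 3-methoxyphenyl is the only group of its kind here and neither 4-methoxyphenyl nor plain phenyl appears among the compounds shown. Also open, going by these compounds, is whether an amine or a carboxylic acid on this phenyl ring would move the number beyond the scatter from compound 1.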